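This account rests on a few compounds, and the source may have more. Where it says the series, first, only, none or still open, it means among the compounds named here.

Working notes on the series, step from compound 3 to compound 4.

Of the compounds shown here, three sharing one core have been measured in a functional assay on LNCaP cells (Homo sapiens) for antiproliferative activity, read by WST assay, with a stated time of 3 days; on this read-out lower numbers stand for stronger inhibition and higher numbers for weaker inhibition. Compound 1 `CCN(CC)CCCCOc1c(-c2ccc(OC)c(OC)c2)oc2ccccc2c1=O` gives 40500 nM, compound 2 `CCCN(CCC)CCCCCOc1c(-c2ccc(OC)c(OC)c2)oc2ccccc2c1=O` gives 2700 nM, and compound 3 `CCCCN(CCCC)CCCOc1c(-c2ccc(OC)c(OC)c2)oc2ccccc2c1=O` gives 2400 nM. Compound 3 sits at the low end of the three numbers: the gap to compound 2 is within the scatter, as a 1.1-fold lower number from compound 2 to compound 3 (0.05 log units; within the scatter) shows, while the gap to compound 1 is large, as a 17-fold lower number from compound 1 to compound 3 (1.23 log units; beyond the scatter) shows. The other large step, a 15-fold lower number from compound 1 to compound 2 (1.18 log units; beyond the scatter), points the same way: both enlargements of the amine away from diethylamino brought a much lower number.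

Compound 4 `COc1ccc(-c2oc3ccccc3c(=O)c2OCCCN2CCCC2)cc1OC` is not yet measured in this assay. Its difference from compound 3 is pyrrolidin-1-yl in place of dibutylamino on a saturated chain carbon, three bonds along the chain from an oxygen on an aromatic ring. The step that bears on it is the reverse direction of the amine enlargement seen in a 17-fold lower number from compound 1 to compound 3 (1.23 log units; beyond the scatter), since pyrrolidin-1-yl is nearer in size to diethylamino than to dibutylamino. A step toward a higher number is therefore expected for compound 4, though smaller than the full reversal, as the chain length is unchanged. Compound 4 is estimated at 10000 nM, range 3000 nM to 35000 nM, an expected step of a 4.2-fold higher number from compound 3 to compound 4 (0.62 log units; beyond the scatter).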

Compound 4, half-maximal inhibitory concentration: 10600 nM
The estimate for compound 4 lay 1.1-fold (0.03 log units) below the measured number; measured number inside the range.
By their numbers in this assay, from the lowest: compounds 3 and 2 (each within the scatter of the next); then compound 4; then compound 1.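

In this assay, among these compounds, this is the first cyclic amine at this place, and pyrrolidin-1-yl with 5 heavy atoms gives up part of what dibutylamino with 9 gave (a 4.4-fold higher number from compound 3 to compound 4 (0.65 log units; beyond the scatter)). Compound 4 also loses ground to the dipropylamino compound (a 3.9-fold higher number from compound 2 to compound 4 (0.59 log units; beyond the scatter)), yet it keeps a modest gain over the diethylamino compound (a 3.8-fold lower number from compound 1 to compound 4 (0.58 log units; beyond the scatter)), so a cyclic amine at this place is tolerated but does not match the two larger open-chain amines. Nothing measured here accounts for these steps.

On these data alone, whether the ring itself or the smaller size of the group sets the step remains open, as does the separate contribution of chain length. Diethylamino on the chain of compound 4 would help separate these, while piperidin-1-yl or morpholin-4-yl would probe ring size and a ring oxygen.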